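Fluoro in Place of Nitro: Compound 4 Expected

This account rests on a few compounds, and the source may have more. Where it says the series, first, only, none or still open, it means among the compounds named here.

Compound 1 `COc1cc(N(C)C(=O)c2cccc([N+](=O)[O-])c2)cc(OC)c1OC` gives >= 125000 nM in a functional assay on Daoy cells (Homo sapiens) for cytotoxicity, read by MTT assay, with a stated time of 72 h (on this read-out lower numbers stand for stronger inhibition and higher numbers for weaker inhibition), a limit of the assay rather than a number. Compound 2 `COc1cc(N(C)C(=O)c2cccc(F)c2)cc(OC)c1OC` gives >= 125000 nM, again a limit. For the measured compounds named here, compound 3 `COc1cc(NC(=O)c2ccc([N+](=O)[O-])cc2)cc(OC)c1OC` gives 52900 nM, the only number among the three. Compound 1 and compound 2 both sit at the limit of the assay (the limit of >= 125000 nM in this assay, at which 2 of the 3 values shown sit).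

From compound 1 to compound 2 the step is a step that the two limits leave unreadable from compound 1 to compound 2, since both values are limits. The change there is fluoro in place of nitro on an aromatic carbon. How the core of compound 3 differs from the core of compound 1 is not broken down here. Compound 4 `COc1cc(NC(=O)c2ccc(F)cc2)cc(OC)c1OC` differs from compound 3 by fluoro in place of nitro on an aromatic carbon. This is the same kind of change as from compound 1 to compound 2, but the place is not the same: there it is meta to a large group, here para to a large group.

With the earlier step unreadable, the expectation for compound 4 rests on compound 3 alone, with its value 52900 nM, and a step of a 1.7-fold higher number from compound 3 to compound 4 (0.23 log units; within the scatter) is expected. Compound 4 is estimated at 90000 nM, between 30000 nM and 150000 nM.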

Compound 4, half-maximal inhibitory concentration: >= 125000 nM
Compound 4 ended at the assay's limit; the forecaster's own chance of this, stated with the estimate: 45%; at least 1.3-fold (0.14 log units) between middle value and limit.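

Fluoro in place of nitro, para to a large group, gives an at least 2.3-fold higher number from compound 3 to compound 4 (0.37 log units; beyond the scatter) in this assay, so on this core the change is readable and raises the number beyond the scatter. The same kind of change on the core of compound 1, meta to a large group, cannot be read, with compound 1 and compound 2 both at a limit, and nothing here shows whether the step carries over from one core to the other or fails to. The new step has a lower bound and no upper one, as compound 4 also stands at a limit rather than at a number: the limit of >= 125000 nM in this assay, at which 3 of the 4 values shown sit.

For the compounds shown here, compound 3 gives 52900 nM, the only number, so it remains open how an amine, a carboxylic acid or a nitrile in the place of its nitro would read. Also open, on these data alone, is whether any such group would bring the core of compound 1 off the limit.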